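This account rests on a few compounds, and the source may have more. Where it says the series, first, only, none or still open, it means among the compounds named here.

Three compounds sharing one core were measured in a functional assay on MV4-11 cells (Homo sapiens) for inhibition, read by resazurin assay, with a stated time of 72 h; on this read-out higher numbers stand for weaker inhibition of growth and lower numbers for stronger inhibition of growth. Compound 1 `O=C1NCCC12CCN(c1c(Cl)cncc1-c1ccsc1)CC2` gives 190 nM, compound 2 `O=C1NCCC12CCN(c1c(Cl)cncc1-c1cc[nH]c1)CC2` gives 1050 nM, and compound 3 `O=Cc1ccc(-c2cncc(Cl)c2N2CCC3(CCNC3=O)CC2)o1` gives 5190 nM. Compound 3 therefore stands highest of the three numbers, meaning the weakest inhibition of growth, and both of its gaps lie beyond the scatter: a 27-fold higher number from compound 1 to compound 3 (1.44 log units; beyond the scatter) and a 4.9-fold higher number from compound 2 to compound 3 (0.69 log units; beyond the scatter).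

Compound 4 `CC(=O)c1ccc(-c2cncc(Cl)c2N2CCC3(CCNC3=O)CC2)s1` differs from compound 3 in one place: 5-acetylthiophen-2-yl in place of 5-formylfuran-2-yl on an aromatic carbon. The measured steps that bear on this are the exchanges of the five-membered ring on the same aromatic carbon, namely a 5.5-fold higher number from compound 1 to compound 2 (0.74 log units; beyond the scatter) and a 27-fold higher number from compound 1 to compound 3 (1.44 log units; beyond the scatter). Both show that the identity of this ring matters, and the thiophene of compound 1 gave the lowest number of all. Compound 4 carries a thiophene again, though now with an acetyl group, so part of the loss seen in compound 3 is expected to be recovered.

For compound 4 in this assay a lower number than compound 3 is expected, about a 3.5-fold lower number from compound 3 to compound 4 (0.54 log units; beyond the scatter), with an estimate of 1500 nM and a likely range from 500 nM to 5000 nM.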

Compound 4, concentration for 50% growth inhibition: 1440 nM
Compound 4: the middle estimate sits 1.0-fold (0.02 log units) above what was measured, and the stated range covers the measured number.
By their numbers in this assay, from the lowest: compound 1; then compounds 2 and 4 (each within the scatter of the next); then compound 3.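

In this assay, 5-acetylthiophen-2-yl in place of 5-formylfuran-2-yl gives a 3.6-fold lower number from compound 3 to compound 4 (0.56 log units; beyond the scatter), so a five-membered ring carrying a carbonyl group on this aromatic carbon need not stand as high as compound 3 does. Having a thiophene at this place is not enough to reach the number of compound 1, since the 5-acetylthiophen-2-yl group gives a 7.6-fold higher number from compound 1 to compound 4 (0.88 log units; beyond the scatter), whereas the comparison with the 1H-pyrrol-3-yl group gives a 1.4-fold higher number from compound 2 to compound 4 (0.14 log units; within the scatter), which leaves compound 2 and compound 4 indistinguishable in this assay. No measurement shown here accounts for any of these steps.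

The step to compound 4 changes the ring and its side group together, so the compounds shown cannot say how much of it belongs to the sulfur in place of the oxygen and how much to the acetyl in place of the formyl; 5-formylthiophen-2-yl or 5-acetylfuran-2-yl would separate the two. Also open, from the compounds shown here alone, is how this position responds when the thiophene carries an amine or a carboxylic acid instead of a carbonyl side group.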